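Azido replaced by a phenyl-bearing triazole

A few compounds are considered here, and "the series" means these few. Any claim that something is new, unique, unknown or untested is made for them only; others in the source may bear on it.

In an ADME assay on microsomes from liver (Homo sapiens) for metabolic stability, read by LC-MS, with NADPH named in the record, with a stated time of 60 min, tested at 1 uM, in the absence of a further agent (a higher number here means that more of the compound is left, a lower number that less of the compound is left), compound 1 (`COc1ccc(-c2c(C)nc3c(N4CC[C@@H](NC(=O)c5ccccc5)C4)cc(C)nn23)cc1OC`) gives > 95% as a limit, not a number. Compound 2 (`COc1ccc(-c2c(C)nc3c(N4CCCC4)cc(C)nn23)cc1OC`) gives > 95% as a limit too. Compound 3 (`COc1ccc(-c2c(C)nc3c(N4CC[C@@H](N=[N+]=[N-])C4)cc(C)nn23)cc1OC`) gives > 95% as a limit as well, so it stands with the other two (the limit of > 95% in this assay, at which 3 of the 3 values shown sit). Compound 4 (`COc1ccc(-c2c(C)nc3c(N4CC[C@@H](n5cc(-c6ccccc6)nn5)C4)cc(C)nn23)cc1OC`) has 4-phenyl-1H-1,2,3-triazol-1-yl in place of azido (4-phenyl-1H-1,2,3-triazol-1-yl in place of azido on a saturated ring carbon). Within the data shown here, two measured steps bear on this (a step that the two limits leave unreadable from compound 2 to compound 3 and a step that the two limits leave unreadable from compound 1 to compound 3) and neither has a readable size. The benzamido group of compound 1 also holds a six-membered aromatic ring of carbon only, and compound 1 still gives > 95% as a limit. No step beyond the scatter is therefore expected in this assay (a number at least 3 percentage points lower from compound 3 to compound 4 (that floor lies within the scatter)). The estimated value for compound 4 is 92% with 72% to 100% as its expected range.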

Compound 4, percent of the compound remaining: "unstable" (no number reported)
The entry for compound 4 holds no number; no gap can be computed for the estimate.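

In this assay compound 4 gives "unstable" (no number reported), so no step can be read from compound 3 to compound 4. The compounds shown leave open how much of compound 4 remains and which part of its 4-phenyl-1H-1,2,3-triazol-1-yl group goes with this result.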